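From Chloro to Methoxy in Compound 3

A few compounds are considered here, and "the series" means these few. Any claim that something is new, unique, unknown or untested is made for them only; others in the source may bear on it.

In an ADME assay on NHDF cells (Homo sapiens) for cytotoxicity, read by MTT assay, with a stated time of 72 h (a higher number here means a weaker inhibitor, a lower number a stronger inhibitor), compound 1 `COc1cccc(/C=C2\CCC/C(=C\c3cccc(Br)c3)C2=O)c1OC` gives 23900 nM and compound 2 `COc1cccc(/C=C2\CCC/C(=C\c3cc(Cl)cc(Cl)c3)C2=O)c1OC` gives 21600 nM on the same scale. Compound 3 `COc1ccc(/C=C2\CCC/C(=C\c3ccccc3Cl)C2=O)cc1OC` gives 21600 nM and so stands level with compound 2, with all three values within the usual scatter of one another. Compound 4 `COc1ccccc1/C=C1\CCC/C(=C\c2ccc(OC)c(OC)c2)C1=O` differs from compound 3 by a single change methoxy in place of chloro on an aromatic carbon that puts methoxy in place of chloro on an aromatic carbon, ortho to a large group. Resting on a 1.1-fold lower number from compound 1 to compound 2 (0.04 log units; within the scatter) as the only measured step, which does not trade chloro for methoxy and so guides only loosely, no change beyond the scatter is expected in this assay for this swap. The estimated step is a 1.0-fold higher number from compound 3 to compound 4 (0.01 log units; within the scatter) at the middle of the range. Compound 4 is expected at 22000 nM with an estimated range from 12000 nM to 40000 nM overall.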

Compound 4, half-maximal inhibitory concentration: 18100 nM
For compound 4 the middle estimate is 1.2-fold (0.08 log units) above the measured one; low and high end bracket the measured number.
By their numbers in this assay, from the lowest: compounds 4, 2, 3 and 1 (each within the scatter of the next).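

In this assay the first measured trade of chloro for methoxy, 2-chlorophenyl to 2-methoxyphenyl, gives a 1.2-fold lower number from compound 3 to compound 4 (0.08 log units; within the scatter) and so does not shift the number beyond the scatter. At this aromatic carbon, ortho to a large group, two heavy atoms including an oxygen can thus replace a single chlorine with no readable change. No measurement offered here accounts for this result.

As far as these compounds go, whether an amine or a carboxylic acid on this carbon would leave the number as unmoved stays open. So does whether this swap reads the same on other aromatic carbons.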